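Furan in place of methoxyphenyl on a dienone chain

This account rests on a few compounds, and the source may have more. Where it says the series, first, only, none or still open, it means among the compounds named here.

The measured compounds and their values in a functional assay on THP-1 cells (Homo sapiens) for inhibition, read by sulforhodamine B assay, with a stated time of 48 h, tested at 50 uM (a lower number here means less inhibition of growth, a higher number more inhibition of growth at the concentration tested), are:
compound 1, `COc1cc(/C=C/C(=O)/C=C/c2cc(OC)c(OC)c(OC)c2)ccc1OCc1cn(CCCOc2cc(=O)oc3ccccc23)nn1`, 79%;
compound 2, `COc1ccc(/C=C/C(=O)/C=C/c2ccc(OCc3cn(CCOc4cc(=O)oc5ccccc45)nn3)c(OC)c2)cc1`, 78%;
compound 3, `COc1cccc(/C=C/C(=O)/C=C/c2ccc(OCc3cn(CCCCOc4cc(=O)oc5ccccc45)nn3)c(OC)c2)c1`, 47%.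

Compound 2 stands second highest of the three numbers. Its nearest neighbour is compound 1, whose value lies within the scatter of that of compound 2, so the two cannot be told apart on these data. Compound 3 is the furthest from compound 2, and that gap lies beyond the scatter. Compound 4, `COc1cc(/C=C/C(=O)/C=C/c2ccco2)ccc1OCc1cn(CCOc2cc(=O)oc3ccccc23)nn1`, has not yet been measured in this assay. It differs from compound 2 in one place: furan-2-yl in place of 4-methoxyphenyl on a double-bonded chain carbon bound to a double-bonded chain carbon. Among the measured compounds shown here, no step between two measured compounds shows what such a change does, so the expectation rests on the spread of the three numbers alone, which spans from compound 3 up to compound 1 and compound 2. Because the value of compound 2 is 78% and a smaller ring enters in place of a larger one, a downward step of modest size, probably beyond the scatter, is expected from compound 2 to compound 4, estimated as a number 18 percentage points lower from compound 2 to compound 4 (beyond the scatter). Compound 4 is therefore expected to give about 60% in this assay, within a range from 35% to 85%.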

Compound 4, percent growth inhibition at one concentration: 78%
For compound 4 the middle estimate is 18 percentage points below the measured one; the measured number falls inside the stated range.
By their numbers in this assay, from the lowest: compound 3; then compounds 2, 4 and 1 (each within the scatter of the next).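

In this assay, among the compounds shown here, replacing 4-methoxyphenyl with furan-2-yl on a double-bonded chain carbon bound to a double-bonded chain carbon gives no change at the digits printed from compound 2 to compound 4 (within the scatter), the only step here that isolates a change in one place. For the compounds shown here, it shows that, at the concentration tested, this position accepts a five-membered aromatic ring with 1 hetero atom and 5 heavy atoms in place of a six-membered aromatic ring of carbon only with 8 heavy atoms, with no readable change in growth inhibition, something the earlier compounds, each differing from the others in more than one place, could not show. No measurement presented here speaks to why the exchange leaves the number where it is.

As far as these compounds go, it remains open whether thiophen-2-yl, a ring bearing an amine, or one bearing a carboxylic acid would behave the same way at this place, and whether furan-2-yl would do so on a longer chain such as that of compound 3. A read-out at a single concentration also leaves open how compound 2 and compound 4 compare at lower concentrations.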